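A few compounds are considered here, and "the series" means these few. Any claim that something is new, unique, unknown or untested is made for them only; others in the source may bear on it.

Measured so far in a functional assay on HL-60 cells (Homo sapiens) for inhibition, read by MTT assay, with a stated time of 72 h; on this read-out lower numbers stand for stronger inhibition and higher numbers for weaker inhibition:
Compound 1 `CCc1nc(-c2ccc(C(C)(C)C)cc2)c(C(=O)N2CCN(c3cccc(OC)c3)CC2)o1`: "not active" (no number reported)
Compound 2 `CCc1nc(-c2ccc(F)cc2)c(C(=O)N2CCN(c3cccc(OC)c3)CC2)o1`: 411 nM

Going by the values given here, compound 2, at 411 nM, is the only compound in this small set with a number, while compound 1 is reported as "not active" (no number reported). The next compound to be tested, compound 3 `CCc1nc(-c2ccccc2F)c(C(=O)N2CCN(c3cccc(OC)c3)CC2)o1`, keeps the shared core of compound 2 and differs from it in one place: 2-fluorophenyl in place of 4-fluorophenyl on an aromatic carbon. It carries 2-fluorophenyl in place of 4-fluorophenyl on an aromatic carbon, so the two have the same atoms, joined differently.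

Among the compounds with values here, no measured pair in this assay shows what a change of this kind does, so the expectation rests on compound 2 at 411 nM alone and remains broad. No shift beyond the usual scatter is expected in either direction, although a result without a number, as for compound 1, cannot be ruled out. The expected change is a 1.2-fold higher number from compound 2 to compound 3 (0.09 log units; within the scatter). The estimated value for compound 3 is 500 nM, with an expected range from 130 nM to 2000 nM.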

Compound 3, half-maximal inhibitory concentration: 607 nM
The estimate for compound 3 lay 1.2-fold (0.08 log units) below the measured number; the range from low to high includes it.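

In this assay, going by these compounds alone, this is the first readable step at this place, the aromatic carbon next to the ring nitrogen and next to the ring atom that bears a large group, and moving from 4-fluorophenyl to 2-fluorophenyl gives a 1.5-fold higher number from compound 2 to compound 3 (0.17 log units; within the scatter). The two compounds have the same atoms joined differently, so this read-out does not separate the two fluorophenyl groups, and a number is obtained with either of them at this place on the shared core. There is no independent measurement that could explain this result, so the step stands as an observation only.

The compounds shown leave open how far this tolerance extends, since fluorine is the only small substituent on this phenyl ring that has a number here, and a single pair cannot show whether other groups would behave alike. As far as these compounds go, it also remains open whether an amine or a carboxylic acid in place of the fluorine, or a longer chain such as butyl in place of the ethyl group, would still give a number in this assay on this read-out.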